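The compounds below may be only part of what the source reports. "The series", "measured", "known", "first", "only" and "open" are said of these compounds alone.

In a functional assay on A549 cells (Homo sapiens) for cytotoxicity, read by MTT assay, with a stated time of 72 h (on this read-out higher numbers stand for weaker inhibition and lower numbers for stronger inhibition), compound 1 (`O=C(/C=C/c1ccc([N+](=O)[O-])cc1)Nc1cc2c(Nc3ccc(F)c(Cl)c3)ncnc2cc1O[C@H]1CCOC1`) gives 12000 nM and compound 3 (`COc1ccc(OC)c(/C=C/C(=O)Nc2cc3c(Nc4ccc(F)c(Cl)c4)ncnc3cc2OC)c1`) gives 11200 nM, so these two values lie within the scatter of each other. Compound 2 (`COc1cc2ncnc(Nc3ccc(F)c(Cl)c3)c2cc1NC(=O)/C=C/c1ccc(F)cc1Cl`) is reported as "not active" (no number reported), with no number. Compound 4 (`COc1ccc(/C=C/C(=O)Nc2cc3c(Nc4ccc(F)c(Cl)c4)ncnc3cc2O[C@H]2CCOC2)c(OC)c1`) has not yet been measured. It differs from compound 1 by 2,4-dimethoxyphenyl in place of 4-nitrophenyl on a double-bonded chain carbon bound to a double-bonded chain carbon, with 2,4-dimethoxyphenyl in place of 4-nitrophenyl on a double-bonded chain carbon bound to a double-bonded chain carbon. No step beyond the scatter is expected in this assay because compound 3, which also bears a dimethoxyphenyl group, gives 11200 nM. The estimated step is a 1.2-fold lower number from compound 1 to compound 4 (0.08 log units; within the scatter), and it is expected to stay within the scatter. The expected value for compound 4 is 10000 nM, with an estimated range of 4000 nM to 25000 nM.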

Compound 4, half-maximal inhibitory concentration: 9350 nM
The estimate for compound 4 lay 1.1-fold (0.03 log units) above the measured number, within the range that was stated.
By their numbers in this assay, from the lowest: compounds 4, 3 and 1 (each within the scatter of the next).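

In this assay the change to 2,4-dimethoxyphenyl in place of 4-nitrophenyl, on a double-bonded chain carbon bound to a double-bonded chain carbon, gives a 1.3-fold lower number from compound 1 to compound 4 (0.11 log units; within the scatter) and so stays within the scatter. This is the first pair shown that differs in one place, and it shows that this position accepts two quite differently substituted phenyl groups with no real change in the number. Nothing measured here bears on why the number holds.
As far as these compounds go, whether an amine or a carboxylic acid on this phenyl group would move the number remains open, as does the effect of a longer chain in place of the ethenyl link.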